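A few compounds are considered here, and "the series" means these few. Any claim that something is new, unique, unknown or untested is made for them only; others in the source may bear on it.

Compound 1 `O=C(Nc1cccc(F)c1)c1cncc(N2CC3CC(C2)N3)c1`: 28 nM
Compound 2 `O=C(c1cncc(N2CC3CC(C2)N3)c1)N1CCc2ccccc2C1`: 21 nM

Both numbers come from an assay on cells for displacement of a labelled ligand from Neuronal acetylcholine receptor; alpha3/beta4 (Homo sapiens); on this read-out lower numbers stand for stronger inhibition and higher numbers for weaker inhibition. Compound 1 has the higher of the two numbers, but compound 2 lies within the scatter of it, so the pair shows no order. Compound 3 `O=C(Nc1ccc(F)cc1F)c1cncc(N2CC3CC(C2)N3)c1` is still to be measured. It differs from compound 1 by 2,4-difluorophenyl in place of 3-fluorophenyl on an amide-type nitrogen. Going by the values given here, no measured pair shows what such a change does here, so nothing beyond the scatter is expected, in no set direction; the expected step is a 1.1-fold higher number from compound 1 to compound 3 (0.03 log units; within the scatter). For compound 3 the estimate in this assay is 30 nM, between 10 nM and 90 nM.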

Compound 3, inhibition constant: 50 nM
Beside the measured number, compound 3's estimate is 1.7-fold (0.22 log units) below it; measured number inside the range.
By their numbers in this assay, from the lowest: compounds 2, 1 and 3 (each within the scatter of the next, the first and the last beyond it).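

Going by these compounds alone, the first step at this place, on an amide-type nitrogen whose other neighbours are: carbonyl carbon, is 2,4-difluorophenyl in place of 3-fluorophenyl. It gives a 1.8-fold higher number from compound 1 to compound 3 (0.25 log units; within the scatter) in this assay and so leaves the read-out within the scatter. This one change therefore shows that the series keeps its range with 2,4-difluorophenyl on this nitrogen. No supporting evidence bears on this result.

Still open, from the compounds shown here alone, is whether the range holds with a simple longer alkyl chain on this nitrogen in place of the aromatic ring. The same question stands for a phenyl ring carrying an amine or a carboxylic acid.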